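The compounds below may be only part of what the source reports. "The series", "measured", "known", "first", "only" and "open" are said of these compounds alone.

For the measured compounds named here, in a physicochemical assay for solubility, with a stated time of 24 h, tested at 30 mg/mL (a lower number here means a less soluble compound, a higher number a more soluble compound), compound 1 (`C[C@H](Nc1c(NCCCCCC(=O)NO)c(=O)c1=O)c1ccccc1`) gives 28000000 nM, the middle of the three numbers measured so far. Compound 2 (`CC[C@H](Nc1c(NCCCCCC(=O)NO)c(=O)c1=O)c1ccccc1`) gives 57000000 nM, and compound 3 (`Cc1ccc([C@H](C)Nc2c(NCCCCCC(=O)NO)c(=O)c2=O)cc1`) gives 5600000 nM. Compound 4 (`Cc1ccc(Nc2c(NCCCCCC(=O)NO)c(=O)c2=O)cc1`) has not yet been measured. The change that leads to it is 4-methylphenyl in place of 1-phenylethyl on a nitrogen on an aromatic ring. Going by the values given here, two measured steps bear on this change, and both are modest. The closer guide is a 5.0-fold lower number from compound 1 to compound 3 (0.70 log units; beyond the scatter), which came with methyl in place of hydrogen on an aromatic carbon, a methyl that compound 4 also carries. The other is a 2.0-fold higher number from compound 1 to compound 2 (0.31 log units; beyond the scatter), which came with methyl in place of hydrogen on a saturated chain carbon. Compound 4 has no 1-phenylethyl group, so this step offers only a weak hint of a further fall. Among the compounds with values here, no measured compound has an aryl group placed on that nitrogen as in compound 4, so the range stays wide. The expected change is a modest to moderate fall, estimated as an 8.0-fold lower number from compound 1 to compound 4 (0.90 log units; beyond the scatter). For compound 4 the estimated value is 3500000 nM, with an expected range from 700000 nM to 17000000 nM.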

Compound 4, solubility: 1800000 nM
For compound 4 the middle estimate is 1.9-fold (0.29 log units) above the measured one, within the range that was stated.
By their numbers in this assay, from the lowest: compound 4; then compound 3; then compound 1; then compound 2.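

In this assay, 4-methylphenyl in place of 1-phenylethyl on a nitrogen on an aromatic ring gives a 16-fold lower number from compound 1 to compound 4 (1.19 log units; beyond the scatter), the largest of the steps from compound 1 and the first to put an aryl group on that nitrogen. The entering group has no defined stereocentre, so this single step cannot separate the loss of the stereocentre from the loss of the saturated carbon that carried the ring in compound 1. Nothing given here accounts for the size of this fall.

The compounds shown leave open whether plain phenyl on that nitrogen would give a number like that of compound 4, and whether benzyl, which keeps a saturated carbon but no stereocentre, would stay nearer compound 1. They also leave open how an amine or a carboxylic acid on the aryl ring would read.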